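The source may report more compounds than this note shows. Statements on the series, on what has been measured and on what is new or still open speak of the compounds shown alone.

Measured compounds:
compound 1 `CC1(CNc2ccc(OC(F)(F)F)cc2)CCn2cc([N+](=O)[O-])nc2O1` — in an ADME assay on MRC5 cells (Homo sapiens) for cytotoxicity, read by resazurin assay, with a stated time of 72 h (on this read-out higher numbers stand for weaker inhibition and lower numbers for stronger inhibition), compound 1 gives >= 40000 nM, which is a limit of the assay and not a number.
compound 2 `CC1(CNc2ccc(F)cc2)CCn2cc([N+](=O)[O-])nc2O1` — in this assay compound 2 gives >= 40000 nM, likewise a limit.

Compound 2 therefore stands only at a limit, the same one at which both recorded values sit (the limit of >= 40000 nM in this assay, at which 2 of the 2 values shown sit). Among the measured compounds shown here, the single measured step, a step that the two limits leave unreadable from compound 1 to compound 2, is left unreadable by the two limits.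

Compound 3 `CN(CC1(C)CCn2cc([N+](=O)[O-])nc2O1)c1ccc(F)cc1` differs from compound 2 by methyl in place of hydrogen on a nitrogen on an aromatic ring. For the measured compounds named here, no measured step bears on a change of this kind, and the one step on record gives no size. The step expected in this assay is a step that the limit leaves unreadable from compound 2 to compound 3, none beyond the scatter. Compound 3 is expected to sit at the same limit, estimated at 60000 nM, with a range from 20000 nM to 200000 nM.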

Compound 3, half-maximal inhibitory concentration: >= 40000 nM
Compound 3 ended at the assay's limit; the forecaster's own chance of this, stated with the estimate: 85%; the middle value lies beyond the limit too.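

No step can be read from compound 2 to compound 3, since both values are limits and not numbers: the limit of >= 40000 nM in this assay, at which 3 of the 3 values shown sit. Still open, as far as these compounds go, is how far compound 1, compound 2 and compound 3 each lie beyond that limit, and so what methyl in place of hydrogen changes.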